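Inverting one chain stereocentre in a gastric antisecretory series

This account rests on a few compounds, and the source may have more. Where it says the series, first, only, none or still open, it means among the compounds named here.

Measured compounds:
compound 1 `CCCC[C@@](C)(OC)[C@H](O)/C=C/C1[C@H](O)C[C@H](O)[C@@H]1C/C=C\CCCC(=O)OC` with 1.5 mg/kg
compound 2 `CCCC[C@](C)(OC)[C@@H](O)/C=C/C1[C@H](O)CC(=O)[C@@H]1C/C=C\CCCC(=O)OC` with 1.5 mg/kg
compound 3 `CCCC[C@](C)(OC)[C@@H](O)/C=C/C1[C@H](O)CC(=O)[C@@H]1CCCCCCC(=O)OC` with > 3 mg/kg

In a functional assay on the whole organism (stomach) with Rattus norvegicus as the target (on this read-out lower numbers stand for an effect already at smaller amounts and higher numbers for an effect only at larger amounts of compound), compound 2 gives 1.5 mg/kg. In this assay compound 1 gives 1.5 mg/kg, so compound 2 stands level with compound 1 at the digits shown, a gap within the scatter. Compound 3 gives only a limit in this assay, > 3 mg/kg, and not a number; (the limit of > 3 mg/kg in this assay, at which 1 of the 3 values shown sits). Among the compounds with values here, the one measured step, an at least 2.0-fold higher number from compound 2 to compound 3 (0.30 log units; that floor lies within the scatter), comes from replacing 5-(methoxycarbonyl)pent-1-en-1-yl by 5-(methoxycarbonyl)pentyl, and its floor lies within the scatter.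

Compound 4 `CCCC[C@](C)(OC)[C@H](O)/C=C/C1[C@H](O)CC(=O)[C@@H]1C/C=C\CCCC(=O)OC` differs from compound 2 in another way: the two compounds have the same atoms and bonds; at least one stereo element is drawn with a configuration in one of them and without one in the other: 1 of 7 stereo elements differ; a stereocentre at a saturated chain carbon is drawn S in compound 2 and R in compound 4. Within the data shown here, no measured step concerns that kind of change, so the step from compound 2 to compound 3 does not bear on it directly and gives no direction. With a stereocentre on the chain drawn the other way, a shift in either direction is possible, and the estimate stays wide.

Compound 4 is therefore expected to show a step of about a 1.7-fold higher number from compound 2 to compound 4 (0.22 log units; within the scatter) in this assay. Compound 4 is estimated at 2.5 mg/kg, within a range from 0.8 mg/kg to 8 mg/kg.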

Compound 4, dose for 50% inhibition: 0.5 mg/kg
For compound 4 the middle estimate is 5.0-fold (0.70 log units) above the measured one; measured number below the stated range.
By their numbers in this assay, from the lowest: compound 4; then compounds 1 and 2 (each within the scatter of the next). At a limit, above all of these: compound 3.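

The inversion of this one stereocentre at a saturated chain carbon, from S in compound 2 to R in compound 4, leaves the atoms and bonds unchanged and still gives a 3.0-fold lower number from compound 2 to compound 4 (0.48 log units; beyond the scatter) in this assay. Unlike the earlier step, which concerned the saturation of the side chain and whose floor stayed within the scatter, this step is printed as beyond it, so the drawn configuration at this position is enough on its own to move the dose, and within this pair the lower number goes with R. The reading carries one reservation, since the two structures are not drawn with equal completeness at the point of difference: the fact that one of compounds 2 and 4 is drawn with a defined configuration and the other without, at the place where they differ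

Going by these compounds, whether the inversion has the same effect with 5-(methoxycarbonyl)pentyl in place of 5-(methoxycarbonyl)pent-1-en-1-yl stays open, and compound 3 offers no number for such a comparison, since its > 3 mg/kg is a limit. Also open, on these data alone, is how the R configuration behaves with a free carboxylic acid in place of the methyl ester, or with a longer chain at the end that carries the methoxy group.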